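From an aldehyde to a hydroxy(sulfo)methyl group

The source may report more compounds than this note shows. Statements on the series, on what has been measured and on what is new or still open speak of the compounds shown alone.

Compound 2, with structure `CC(C)C[C@H](NC(=O)OC1CCCCC1)C(=O)N[C@H](C=O)C[C@@H]1CCNC1=O`, is measured in a toxicity assay on L929 cells (Mus musculus) for cytotoxicity (on this read-out lower numbers stand for higher toxicity in this test and higher numbers for lower toxicity in this test), as > 100000 nM, which is a limit of the assay rather than a number. Within the data shown here, its one measured neighbour, compound 1 `CC(C)C[C@H](NC(=O)OC1CCC(F)(F)CC1)C(=O)N[C@H](C=O)C[C@@H]1CCNC1=O`, likewise gives > 100000 nM in this assay, again a limit. The step that the two limits leave unreadable from compound 1 to compound 2 therefore cannot be read, as the limit of > 100000 nM in this assay, at which 2 of the 2 values shown sit, shows. Compound 3 `CC(C)C[C@H](NC(=O)OC1CCCCC1)C(=O)N[C@@H](C[C@@H]1CCNC1=O)C(O)S(=O)(=O)O` differs from compound 2 thus: hydroxy(sulfo)methyl in place of formyl on a saturated chain carbon bound to an amide-type nitrogen and a saturated chain carbon. Among the measured compounds shown here, no measured step bears on this change. For compound 3 a result at the same limit is expected, the step of a number no higher from compound 2 to compound 3 (the limit leaves the size open) lying within the scatter. The estimate for compound 3 is 100000 nM, between 50000 nM and 200000 nM.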

Compound 3, half-maximal cytotoxic concentration: > 100000 nM
Compound 3: no number, only a limit (the forecaster's own chance of this, stated with the estimate: 85%); the middle value sits exactly at the limit.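

No step can be read from compound 2 to compound 3, since both results are limits of the assay rather than numbers: the limit of > 100000 nM in this assay, at which 3 of the 3 values shown sit.

Going by these compounds, whether compound 2 and compound 3 differ at all in this assay, and by how much, stays open.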